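This account rests on a few compounds, and the source may have more. Where it says the series, first, only, none or still open, it means among the compounds named here.

Measured compounds:
compound 1 `CCN1CCN(C(=S)SCC(O)Cn2cc([N+](=O)[O-])nc2C)CC1`, > 5000000 nM in a toxicity assay on HeLa cells (Homo sapiens) for cytotoxicity, read by MTT assay, with a stated time of 24 h; on this read-out lower numbers stand for stronger inhibition and higher numbers for weaker inhibition
compound 2 `CCOC(=O)N1CCN(C(=S)SCC(O)Cn2cc([N+](=O)[O-])nc2C)CC1`, 2360000 nM in this assay

Compound 1 reaches only the limit of this assay: its value, > 5000000 nM, is a limit and not a number (the limit of > 5000000 nM in this assay, at which 1 of the 2 values shown sits). Among the measured compounds shown here, compound 2 gives 2360000 nM in this assay, and the step of an at least 2.1-fold lower number from compound 1 to compound 2 (0.32 log units; beyond the scatter) is the only measured step.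

Compound 3 `Cc1nc([N+](=O)[O-])cn1CC(O)CSC(=S)N1CCCC(C)C1` is not yet measured. Its change from compound 1 is 3-methylpiperidin-1-yl in place of 4-ethylpiperazin-1-yl on a thiocarbonyl carbon. For the measured compounds named here, the one measured step concerns ethoxycarbonyl in place of ethyl on an amine nitrogen in a ring, a different change at a different place, so it offers no direct guide here; the single anchor is that compound 1 sits at the limit of this assay. The expected step of an at least 1.6-fold lower number from compound 1 to compound 3 (0.22 log units; that floor lies within the scatter) is therefore small, quite possibly none beyond the scatter. Compound 3 is estimated at 3000000 nM in this assay, with a range from 1000000 nM to 10000000 nM.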

Compound 3, half-maximal inhibitory concentration: 2700000 nM
Compound 3: the middle estimate sits 1.1-fold (0.05 log units) above what was measured; measured number inside the range.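

Until now the ring on the thiocarbonyl carbon stayed in place and only the group on its amine nitrogen changed; compound 3 replaces the ring itself. In this assay, 3-methylpiperidin-1-yl in place of 4-ethylpiperazin-1-yl gives an at least 1.8-fold lower number from compound 1 to compound 3 (0.26 log units; that floor lies within the scatter), so this position also allows a measured number without the ethoxycarbonyl group of compound 2, though the printed floor does not establish a change beyond the scatter. The true size of this step stays unknown because compound 1 is held at a limit and not a number: the limit of > 5000000 nM in this assay, at which 1 of the 3 values shown sits.

From the compounds shown here alone, how a morpholin-4-yl or an unsubstituted piperidin-1-yl on the thiocarbonyl carbon would read stays open, as does the contribution of the methyl group in 3-methylpiperidin-1-yl. Also open, going by these compounds, is how changes to the shared core, such as an amine in place of the nitro group, would read in this assay.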